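The source may report more compounds than this note shows. Statements on the series, on what has been measured and on what is new or still open speak of the compounds shown alone.

Of the compounds shown here, three sharing one core have been measured so far. In a functional assay on KG-1a cells (Homo sapiens) for cytotoxicity, with a stated time of 24 h (on this read-out higher numbers stand for weaker inhibition and lower numbers for stronger inhibition), compound 1 `Nn1c(SCc2ccc([N+](=O)[O-])cc2)nnc1-c1c[nH]c2ccccc12` gives 6900 nM and compound 2 `Nn1c(SCc2ccc(F)cc2)nnc1-c1c[nH]c2ccccc12` gives 13200 nM, while compound 3 `COc1cccc(CSc2nnc(-c3c[nH]c4ccccc34)n2N)c1` gives 12900 nM in the same test. The value of compound 3 lies within the scatter of both others, so the three cannot be ranked.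

Compound 4 `COc1ccc(CSc2nnc(-c3c[nH]c4ccccc34)n2N)cc1` has the same atoms as compound 3, joined differently, and the whole difference is 4-methoxyphenyl in place of 3-methoxyphenyl on a saturated chain carbon bound to a sulfur in the group on a saturated chain carbon bound to a sulfur. Among the compounds with values here, no measured pair shows a methoxy group changing place in this way, so the evidence is indirect. Fluoro in place of nitro on an aromatic carbon gave a 1.9-fold higher number from compound 1 to compound 2 (0.28 log units; within the scatter) and 3-methoxyphenyl in place of 4-fluorophenyl gave a 1.0-fold lower number from compound 2 to compound 3 (0.01 log units; within the scatter) on that same chain carbon, so no step beyond the scatter is expected in this assay and no direction is favoured. The estimated step is a 1.1-fold lower number from compound 3 to compound 4 (0.05 log units; within the scatter) and it is expected to stay within the scatter. Compound 4 is therefore expected at 11500 nM with an estimated range from 6000 nM to 22000 nM in this read-out.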

Compound 4, half-maximal inhibitory concentration: > 100000 nM
Compound 4 gave a limit, no number; the forecaster's own chance of this, stated with the estimate: 4%; at least 8.6-fold (0.93 log units) between middle value and limit.
By their numbers in this assay, from the lowest: compounds 1, 3 and 2 (each within the scatter of the next). At a limit, above all of these: compound 4.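

In this assay, within the data shown here, moving the methoxy group from 3-methoxyphenyl to 4-methoxyphenyl on a saturated chain carbon bound to a sulfur gives the first change beyond the scatter, with an at least 7.7-fold higher number from compound 3 to compound 4 (0.88 log units; beyond the scatter). Compound 4 gives a limit, not a number: the limit of > 100000 nM in this assay, at which 1 of the 4 values shown sits. Methoxy in place of fluoro gives an at least 7.5-fold higher number from compound 2 to compound 4 (0.87 log units; beyond the scatter), and methoxy in place of nitro gives an at least 14-fold higher number from compound 1 to compound 4 (1.16 log units; beyond the scatter), so the methoxy group is not tolerated everywhere on this ring, since compound 3 carries it without such a step, and the aromatic carbon it occupies in compound 4 is not closed to all groups, since fluoro and nitro stand there in compounds 2 and 1.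

The compounds shown leave open whether this step belongs to methoxy alone or would also appear with an ethoxy group or an amine on that aromatic carbon. They also give no reason for the step, and the limit of compound 4 leaves its true size unknown.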